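From Chloro to Acetamido: Expecting a Small Step

The source may hold more compounds than are shown below. What is called first, only, known or untested is meant among the compounds shown, and "the series" means these compounds.

- Compound 1 `O=C1/C(=C/c2ccncc2)CN(S(=O)(=O)c2ccc(F)cc2)C/C1=C\c1ccccc1F`: 9100 nM
- Compound 2 `O=C1/C(=C/c2ccncc2)CN(S(=O)(=O)c2ccc(Cl)cc2)C/C1=C\c1ccccc1F`: 12500 nM

Both values come from a functional assay on QGY-7703 cells (Homo sapiens) for cytotoxicity, read by MTT assay, with a stated time of 24 h; on this read-out higher numbers stand for weaker inhibition and lower numbers for stronger inhibition. Compound 2 lies within the usual scatter of compound 1, so these two compounds cannot be ranked. The next compound, compound 3 `CC(=O)Nc1ccc(S(=O)(=O)N2C/C(=C\c3ccncc3)C(=O)/C(=C/c3ccccc3F)C2)cc1`, has not yet been measured. It keeps the rest of compound 2 and differs at one group: acetamido in place of chloro on an aromatic carbon. In words, this is acetamido in place of chloro on an aromatic carbon, or 4-chlorophenyl to 4-acetamidophenyl.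

For the measured compounds named here, only one measured step bears on this change. It is a 1.4-fold higher number from compound 1 to compound 2 (0.14 log units; within the scatter), and it lies within the scatter. That step involves chloro, the group that leaves here, but it replaces chloro's counterpart with another single atom rather than a larger group such as acetamido. The data therefore show no direction for the new change, and the best guide is the value of compound 2, 12500 nM. In this assay the expected change is a 1.1-fold lower number from compound 2 to compound 3 (0.06 log units; within the scatter), which means no expected step beyond the scatter. For compound 3 the estimated value is 11000 nM, with an expected range from 4500 nM to 27000 nM.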

Compound 3, half-maximal inhibitory concentration: 13700 nM
Compound 3: the middle estimate sits 1.2-fold (0.10 log units) below what was measured, and the stated range covers the measured number.
By their numbers in this assay, from the lowest: compounds 1, 2 and 3 (each within the scatter of the next).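

In this assay, this position, para to a large group on the aromatic ring, has now held more than a single halogen atom: acetamido brings 4 heavy atoms, 1 hydrogen-bond donor and 1 hydrogen-bond acceptor where chloro has 1 heavy atom and neither of the others, yet the step stays small (a 1.1-fold higher number from compound 2 to compound 3 (0.04 log units; within the scatter)). The comparison with the fluoro compound reads the same way (a 1.5-fold higher number from compound 1 to compound 3 (0.18 log units; within the scatter)), so the fluoro, chloro and acetamido groups cannot be ranked at this position, and the much larger group has not moved the number beyond the scatter. Nothing in the available data gives a reason for this flat result.

From the compounds shown here alone, it remains open whether a group of another kind at this position, such as an amine, a carboxylic acid or a longer chain in place of the acetamido methyl, would also stay within the scatter or would finally shift the number. These compounds also vary only this one place, so they say nothing about how changes elsewhere on the shared core would act.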